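A Methoxy Group Added to the Shared Core

The source may report more compounds than this note shows. Statements on the series, on what has been measured and on what is new or still open speak of the compounds shown alone.

Of the compounds shown here, three have been measured in a functional assay on MCF7 cells (Homo sapiens) for cytotoxicity, read by MTT assay, with a stated time of 48 h; a higher number here means a weaker inhibitor, a lower number a stronger inhibitor. Compound 1 `O=[N+]([O-])c1cc(-c2nc3ccc([N+](=O)[O-])cc3[nH]2)cc(-c2nc3ccc([N+](=O)[O-])cc3[nH]2)c1` gives 1200 nM, compound 2 `Clc1ccc2nc(-c3cccc(-c4nc5ccc(Cl)cc5[nH]4)c3)[nH]c2c1` gives 25900 nM, and compound 3 `FC(F)(F)c1ccc2nc(-c3cccc(-c4nc5ccc(C(F)(F)F)cc5[nH]4)c3)[nH]c2c1` gives 12800 nM. Compound 3 thus holds the second highest of the three numbers: compound 2 lies somewhat above it, beyond the scatter, while compound 1 lies far below it.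

Compound 4 `COc1cc(-c2nc3ccc(C(F)(F)F)cc3[nH]2)cc(-c2nc3ccc(C(F)(F)F)cc3[nH]2)c1` differs from compound 3 by a single change: methoxy in place of hydrogen on an aromatic carbon. Within the data shown here, no pair of measured compounds shows what such an addition does in this assay, so the expectation rests on the change alone. The expected step is a 1.2-fold lower number from compound 3 to compound 4 (0.07 log units; within the scatter), small and in no firm direction. Compound 4 is estimated at 11000 nM, within a range from 4000 nM to 30000 nM.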

Compound 4, half-maximal inhibitory concentration: 11900 nM
Compound 4: middle estimate off by 1.1-fold (0.03 log units), on the low side; low and high end bracket the measured number.
By their numbers in this assay, from the lowest: compound 1; then compounds 4 and 3 (each within the scatter of the next); then compound 2.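

Putting methoxy in place of hydrogen on this aromatic carbon, meta to two large groups, gives a 1.1-fold lower number from compound 3 to compound 4 (0.03 log units; within the scatter) in this assay. So at this position, on this core, the added group leaves the number indistinguishable from that of the parent compound. Nothing available explains this result.

On these data alone, whether an amine or a carboxylic acid on the same carbon would move the number remains open. So does whether methoxy would behave the same way in compound 2.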